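The compounds below may be only part of what the source reports. "The series", "measured", "known", "first", "only" and "open" are said of these compounds alone.

Three compounds carry the same kind of change in two different settings. Compound 2 `CCN1C(=O)N[C@@](CN2Cc3ccc(OC)cc3C2=O)(c2cc3ncccc3o2)C1=O` and compound 1 `COc1ccc2c(c1)C(=O)N(C[C@@]1(c3cc4ncccc4o3)NC(=O)N(C)C1=O)C2` share one core and differ only by hydrogen in place of methyl on a saturated chain carbon bound to an amide-type nitrogen in a ring. In an ADME assay on the whole organism for pharmacokinetics, with Rattus norvegicus as the target, read by LC-MS, at a dose of 10 mg/kg by the oral route (a higher number here means more compound in the circulation at the dose given, a lower number less compound in the circulation), compound 2 gives 378 ng.h/mL, and compound 1 gives 366 ng.h/mL; the step of a 1.0-fold lower number from compound 2 to compound 1 (0.01 log units; within the scatter) is therefore flat. Compound 3 `CCN1CCN(c2ccc3oc([C@]4(CN5Cc6ccc(OC)c(F)c6C5=O)NC(=O)N(COC(=O)C(C)(C)C)C4=O)cc3n2)CC1` belongs to a different core, and the difference between the two cores is not broken down here. In this assay compound 3 gives 12700 ng.h/mL, the highest of the three numbers and well beyond the scatter from both compound 2 and compound 1.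

Compound 4 `COc1ccc2c(c1F)C(=O)N(C[C@@]1(c3cc4nc(N5CCN(C)CC5)ccc4o3)NC(=O)N(COC(=O)C(C)(C)C)C1=O)C2` is related to compound 3 by hydrogen in place of methyl on a saturated chain carbon bound to an amine nitrogen in a ring. For the measured compounds named here, this is the same kind of change as the one between compound 2 and compound 1, but not the same: in the earlier pair the carbon is bound to an amide-type nitrogen in a ring, whereas here it is bound to an amine nitrogen in a ring. Going by the values given here, the only guide for compound 4 is the measured step from compound 2 to compound 1, which stayed within the scatter, so compound 4 is expected to stay close to compound 3, with a step of about a 1.2-fold lower number from compound 3 to compound 4 (0.06 log units; within the scatter). The estimate for compound 4 in this assay is accordingly 11000 ng.h/mL, expected to lie between 4500 ng.h/mL and 27000 ng.h/mL.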

Compound 4, area under the concentration-time curve: 5350 ng.h/mL
Compound 4: the middle estimate sits 2.1-fold (0.31 log units) above what was measured; the measured number falls inside the stated range.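

Shortening the 4-ethylpiperazin-1-yl group of compound 3 to the 4-methylpiperazin-1-yl group of compound 4, which puts hydrogen in place of methyl on a saturated chain carbon bound to an amine nitrogen in a ring, gives in this assay a 2.4-fold lower number from compound 3 to compound 4 (0.38 log units; beyond the scatter). This modest step looks larger than the earlier flat one, but the two cannot be told apart: the same change on two cores in this assay, a 1.0-fold lower number (0.01 log units; within the scatter) from compound 2 to compound 1 and a 2.4-fold lower number (0.38 log units; beyond the scatter) from compound 3 to compound 4, 2.3-fold (0.36 log units) apart, within the scatter of two such steps

The comparison therefore shows that, on these two cores, the change gives steps that do not differ beyond the scatter, but it does not show that the change carries over unaltered, since it rests on a single pair per core and the carbon is bound to an amide-type nitrogen in one pair and to an amine nitrogen in the other.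

The compounds shown leave open how the number in this assay would respond to a longer chain such as propyl on the piperazine nitrogen, or to a bare hydrogen there in place of the alkyl group. They also leave open whether the step seen from ethyl to methyl on the piperazine would recur on a core without the pivaloyloxymethyl group.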